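The compounds below may be only part of what the source reports. "The series", "measured", "known", "first", "only" and "open" are said of these compounds alone.

Compound 1, `CS(=O)(=O)Nc1ccc2c(c1)S(=O)(=O)N=C(C1=C(O)C3CCCC3N(CC3CCC3)C1=O)N2`: > 33000 nM
Compound 2, `CS(=O)(=O)Nc1ccc2c(c1)S(=O)(=O)N=C(C1=C(O)C3CCCC3N(c3ccccc3)C1=O)N2`: "not determined" (no result reported)

Both compounds share one core and differ only in the group on the amide-type nitrogen of the ring. In an ADME assay on Huh-7 cells (Homo sapiens) for cytotoxicity, with a stated time of 72 h (a higher number here means that more compound is tolerated, a lower number that less compound is tolerated), compound 1 gives > 33000 nM; this is a limit of the assay and not a number. Compound 2 in this assay shows "not determined" (no result reported), so there is no single number for it. Among the measured compounds shown here, the only value standing beside compound 2 is the limit of > 33000 nM in this assay, at which 1 of the 2 values shown sits.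

Compound 3, `CS(=O)(=O)Nc1ccc2c(c1)S(=O)(=O)N=C(C1=C(O)C3CCCC3N(Cc3ccccn3)C1=O)N2`, has not yet been measured. It differs from compound 2 by (pyridin-2-yl)methyl in place of phenyl on an amide-type nitrogen in a ring. For the measured compounds named here, no step between measured compounds exists to gauge this change, and in this assay no step beyond the scatter is expected in either direction. Compound 3 is estimated to give about 33000 nM in this assay, expected to fall between 15000 nM and 60000 nM, and most likely reported only as a limit.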

Compound 3, half-maximal cytotoxic concentration: > 33000 nM
Compound 3: only a limit was reported (the forecaster's own chance of this, stated with the estimate: 75%); the middle value sits exactly at the limit.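

In this assay compound 3 gives > 33000 nM, a limit of the assay and not a number. Among the compounds shown here, compound 1 also has only a limit, so no step between compound 1 and compound 3 can be read. The compounds shown leave open whether changing the group on the amide-type nitrogen in the ring alters the half-maximal cytotoxic concentration at all.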